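From neopentyl to isopropyl on a carbonyl carbon

This account rests on a few compounds, and the source may have more. Where it says the series, first, only, none or still open, it means among the compounds named here.

For the measured compounds named here, in a toxicity assay on KB cells (Homo sapiens) for cytotoxicity, read by fluorescence, with a stated time of 3 days (a lower number here means that less compound is needed, a higher number that more compound is needed for the effect), compound 3 `CCCCOC(=O)CNC(=O)[C@H](CSc1ccc([N+](=O)[O-])cc1[N+](=O)[O-])NC(=O)CC[C@H](NC(=O)CC(C)(C)C)C(=O)OCCCC` gives 250 uM, the higher of the two actual numbers so far. Its nearest neighbour on that scale is compound 1 `CCCCOC(=O)CNC(=O)[C@H](CSc1ccc([N+](=O)[O-])cc1[N+](=O)[O-])NC(=O)CC[C@H](NC(=O)CC(C)C)C(=O)OCCCC` at 59.6 uM. Compound 2 `CCCCOC(=O)CNC(=O)[C@H](CSc1ccc([N+](=O)[O-])cc1[N+](=O)[O-])NC(=O)CC[C@H](NC(C)=O)C(=O)OCCCC` reads > 300 uM, which is a limit of the assay and not a number.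

Compound 4 `CCCCOC(=O)CNC(=O)[C@H](CSc1ccc([N+](=O)[O-])cc1[N+](=O)[O-])NC(=O)CC[C@H](NC(=O)C(C)C)C(=O)OCCCC` carries isopropyl in place of neopentyl on a carbonyl carbon. Going by the values given here, no measured step makes this exact swap, so two related steps must serve as a guide. Adding a methyl gave a 4.2-fold higher number from compound 1 to compound 3 (0.62 log units; beyond the scatter). Removing the isopropyl gave an at least 5.0-fold higher number from compound 1 to compound 2 (0.70 log units; beyond the scatter). Both changes moved away from compound 1, so its chain gives the lowest number of the three. Compound 4 keeps an isopropyl end, as compound 1 does, but on the carbonyl carbon itself, so it may recover part of that gap. The expected change is a modest one towards a lower number, a 2.1-fold lower number from compound 3 to compound 4 (0.32 log units; beyond the scatter). Compound 4 is estimated at 120 uM, with an expected range of 45 uM to 300 uM.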

Compound 4, concentration for half-maximal effect: > 300 uM
Compound 4 was reported as a limit; the forecaster's own chance of this, stated with the estimate: 20%; middle value at least 2.5-fold (0.39 log units) away from the limit.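

The new result shows that compound 1's isobutyl cannot be shortened to isopropyl on this carbonyl carbon without losing ground in this assay: the change gives an at least 5.0-fold higher number from compound 1 to compound 4 (0.70 log units; beyond the scatter), and compound 1 now has the lowest number, with steps beyond the scatter to all three other compounds. Replacing neopentyl with isopropyl gives an at least 1.2-fold higher number from compound 3 to compound 4 (0.07 log units; that floor lies within the scatter), so this step does not show that either group gives a clearly different number. Compound 2 and compound 4 both stand at a limit of the assay, and the step between them cannot be read: the limit of > 300 uM in this assay, at which 2 of the 4 values shown sit.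

As far as these compounds go, it remains open whether the lower number belongs to isobutyl specifically or to chains of similar length more generally. A straight butyl chain or a cyclopentyl group on the same carbonyl carbon would help separate these possibilities.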